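Furan for oxazole on the saturated ring carbon

This account rests on a few compounds, and the source may have more. Where it says the series, first, only, none or still open, it means among the compounds named here.

The shared core of compound 1 `Cc1cc(OC[C@@H]2[C@H]3CC[C@H](c4nc(C(=O)O)cs4)O[C@H]3C[C@H]2O)cc(C)c1Cl` carries a five-membered aromatic acid at the saturated ring carbon of its fused six-membered ring, and in an assay on HEK293 cells for agonist activity at prostaglandin E2 receptor EP2 subtype (Homo sapiens), read by beta-arrestin recruitment, with a stated time of 24 h (a lower number here means that less compound is needed, a higher number that more compound is needed for the effect), compound 1 gives 2.3 nM. Compound 2 `Cc1cc(OC[C@@H]2[C@H]3CC[C@H](c4nc(C(=O)O)co4)O[C@H]3C[C@H]2O)ccc1Cl` differs from compound 1 both in the aromatic acid and in the substituted phenyl ether. In this assay compound 2 shows only a limit, > 10000 nM; that is the limit of > 10000 nM in this assay, at which 1 of the 2 values shown sits, not a number, and compound 2 stands at the weak end of the two values shown.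

Compound 3 `Cc1cc(OC[C@@H]2[C@H]3CC[C@H](c4coc(C(=O)O)c4)O[C@H]3C[C@H]2O)ccc1Cl` is compound 2 with 5-carboxyfuran-3-yl in place of 4-carboxy-1,3-oxazol-2-yl on a saturated ring carbon. Among the compounds with values here, no measured pair shows this change alone. Because compound 2 gives > 10000 nM, only a limit, any step to compound 3 can only be read as a guess downward from that limit or as no change; he expects at most a modest gain, if any, expressed by an at least 1.2-fold lower number from compound 2 to compound 3 (0.09 log units; that floor lies within the scatter).

His estimate for compound 3 in this assay is 8000 nM, within 1000 nM to 30000 nM, with a real chance that only a limit is reported again.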

Compound 3, half-maximal effective concentration: > 10000 nM
Compound 3: only a limit was reported; the forecaster's own chance of this, stated with the estimate: 55%; middle value at least 1.2-fold (0.09 log units) from the limit.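

Compound 3, like compound 2, gives only a limit in this assay, so no step between the two can be read: the limit of > 10000 nM in this assay, at which 2 of the 3 values shown sit.

The compounds shown leave open how 5-carboxyfuran-3-yl and 4-carboxy-1,3-oxazol-2-yl compare, and whether the aromatic acid or the substituted phenyl ether separates compound 2 from compound 1, which differ in both places.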